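This account rests on a few compounds, and the source may have more. Where it says the series, first, only, none or still open, it means among the compounds named here.

Measured compounds:

Compound 1, `CC1(C)N=C(N)N=C(N)N1c1ccc(SCC(=O)Nc2ccc(S(=O)(=O)F)cc2)c(Cl)c1`, in an assay on isolated protein for inhibition of Dihydrofolate reductase (Mus musculus) (on this read-out higher numbers stand for higher potency (the scale is a negative logarithm) and lower numbers for lower potency), gives 7.42.
Compound 2, `CC1(C)N=C(N)N=C(N)N1c1ccc(OCc2cccc(C(=O)Nc3cccc(S(=O)(=O)F)c3)c2)c(Cl)c1`, in this assay gives 7.24.
Compound 3, `CC1(C)N=C(N)N=C(N)N1c1ccc(SCC(=O)Nc2cccc(S(=O)(=O)F)c2)c(Cl)c1`, in this assay gives 7.66.

Compounds 1 and 3 share a core and differ only in one place: 4-(fluorosulfonyl)phenyl in place of 3-(fluorosulfonyl)phenyl on an amide-type nitrogen. That change gave a number 0.24 log units lower from compound 3 to compound 1 (within the scatter). Compound 2 carries a different core; the difference between the two cores is not broken down here. Compound 4, `CC1(C)N=C(N)N=C(N)N1c1ccc(OCc2cccc(C(=O)Nc3ccc(S(=O)(=O)F)cc3)c2)c(Cl)c1`, has not yet been measured. It is related to compound 2 by the same change: 4-(fluorosulfonyl)phenyl in place of 3-(fluorosulfonyl)phenyl on an amide-type nitrogen. Among the measured compounds shown here, the place of the change is the same, so the change is the same kind as the one between compound 3 and compound 1.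

The step from compound 2 to compound 4 in this assay is therefore expected to be about a number 0.19 log units lower from compound 2 to compound 4 (within the scatter), resting on the measured step from compound 3 to compound 1, a number 0.24 log units lower from compound 3 to compound 1 (within the scatter). For compound 4 the estimate in this assay is 7.05, with a range from 6.6 to 7.5.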

Compound 4, logarithm of the reciprocal of the active concentration, log(1/C): 6.92
The estimate for compound 4 lay 0.13 log units above the measured number, and the stated range covers the measured number.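

In this assay, putting 4-(fluorosulfonyl)phenyl in place of 3-(fluorosulfonyl)phenyl on an amide-type nitrogen gave a number 0.32 log units lower from compound 2 to compound 4 (beyond the scatter) on this second core. Set beside the earlier step, the change carried over from one core to the other with no detectable difference in size: the same change on two cores in this assay, a number 0.24 log units lower (within the scatter) from compound 3 to compound 1 and a number 0.32 log units lower (beyond the scatter) from compound 2 to compound 4, 0.08 log units apart, within the scatter of two such steps. This holds for these two cores only, and it shows neither that the step would carry to a third core nor why the two steps agree.

The compounds shown leave open whether the step depends on the fluorosulfonyl group itself. A sulfonamide or a carboxylic acid at the same two ring positions would test this.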